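From compound 3 to compound 4: one group exchanged

A few compounds are considered here, and "the series" means these few. Any claim that something is new, unique, unknown or untested is made for them only; others in the source may bear on it.

Measured in a functional assay on MCF7 cells (Homo sapiens) for cytotoxicity, read by MTT assay, with a stated time of 72 h; on this read-out higher numbers stand for weaker inhibition and lower numbers for stronger inhibition:
Compound 1 `COc1cc2ncnc(Nc3ccc(F)c(Cl)c3)c2cc1NC(=O)N/N=C/c1ccc([N+](=O)[O-])cc1` gives 36800 nM
Compound 2 `COc1cc2ncnc(Nc3ccc(F)c(Cl)c3)c2cc1NC(=O)N/N=C/c1ccc(F)cc1Cl` gives "not active" (no number reported)
Compound 3 `COc1cc2ncnc(Nc3ccc(F)c(Cl)c3)c2cc1NC(=O)N/N=C/c1cccc(Cl)c1Cl` gives 28700 nM

Among the compounds with values here, compound 3 stands within the scatter of compound 1, the only other compound with a number, while compound 2 has none. Compound 4 `COc1ccc(/C=N/NC(=O)Nc2cc3c(Nc4ccc(F)c(Cl)c4)ncnc3cc2OC)cc1`, still unmeasured, carries 4-methoxyphenyl in place of 2,3-dichlorophenyl on a carbon with a double bond to nitrogen here. Within the data shown here, one measured step bears on this place: a 1.3-fold lower number from compound 1 to compound 3 (0.11 log units; within the scatter) stayed within the scatter. Compound 2 shows, however, that a change here can also leave no number. No step beyond the scatter is therefore expected in this assay for this exchange. The estimated step is a 1.1-fold higher number from compound 3 to compound 4 (0.05 log units; within the scatter) and it is expected to stay within the scatter. Compound 4 is estimated at 32000 nM with an expected range from 12000 nM to 80000 nM.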

Compound 4, half-maximal inhibitory concentration: 8140 nM
Compound 4: the middle estimate sits 3.9-fold (0.59 log units) above what was measured, outside the stated range (below it).
By their numbers in this assay, from the lowest: compound 4; then compounds 3 and 1 (each within the scatter of the next).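

In this assay, within the data shown here, an exchange at this place gave a step beyond the scatter for the first time: 4-methoxyphenyl brought a 3.5-fold lower number from compound 3 to compound 4 (0.55 log units; beyond the scatter) as well as a 4.5-fold lower number from compound 1 to compound 4 (0.66 log units; beyond the scatter) and compound 4 thus holds the lowest number of the three. The group on the carbon with a double bond to nitrogen can therefore move this number, which the earlier step between numbered compounds had not shown. Nothing available here explains the shift. The compounds shown leave open whether the step goes with the methoxy group itself or with the loss of the chlorine atoms, and whether a hydroxy or dimethylamino group in its place would give a similar number.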